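The compounds below may be only part of what the source reports. "The series", "measured", "known", "first", "only" and "open" are said of these compounds alone.

Compounds measured in a functional assay on DLD-1 cells (Homo sapiens) for antiproliferative activity, read by CellTiter-Glo, with a stated time of 72 h; on this read-out lower numbers stand for stronger inhibition and higher numbers for weaker inhibition:
compound 1 `CC1CCN(C2CCN(S(=O)(=O)c3cnc(Cl)s3)CC2)CC1` — 1800 nM
compound 2 `CC1CCN(C2CCN(S(=O)(=O)c3sc(Cl)nc3C3CC3)CC2)CC1` — > 5000 nM
compound 3 `Cc1cc(C)c(S(=O)(=O)N2CCC(C(=O)N3CCC(C)CC3)CC2)c(C)c1` — > 5000 nM

Compound 1 stands alone as the only numerical result here. For compound 2 the assay gives only a limit, > 5000 nM. For compound 3 the assay likewise gives only a limit, > 5000 nM. For the measured compounds named here, the one measured step, an at least 2.7-fold higher number from compound 1 to compound 2 (0.44 log units; beyond the scatter), concerns cyclopropyl in place of hydrogen on an aromatic carbon of the shared core, and it pushed the value past the limit of this assay.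

Compound 4 `CC1CCN(C2CCN(S(=O)(=O)c3ccc(Cl)cc3Cl)CC2)CC1` arises from compound 1 through (2,4-dichlorophenyl in place of 2-chloro-1,3-thiazol-5-yl on a sulfonyl sulfur). Going by the values given here, no measured step touches this change: the step from compound 1 to compound 2 alters a substituent on the ring that is now exchanged, and compound 3 differs from compound 1 in more than one place, so its value shows only that it, too, sits at the limit. The size and direction of the expected step, a 1.7-fold higher number from compound 1 to compound 4 (0.22 log units; within the scatter), therefore rest on weak footing. Because (the limit of > 5000 nM in this assay, at which 2 of the 3 values shown sit), a result at the limit is a real possibility for compound 4. Compound 4 is expected at 3000 nM in this assay, with a range from 800 nM to 10000 nM.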

Compound 4, half-maximal inhibitory concentration: 1 nM
The estimate for compound 4 lay 3000-fold (3.48 log units) above the measured number, outside the stated range (below it).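

In this assay, for the compounds shown here, placing 2,4-dichlorophenyl in place of 2-chloro-1,3-thiazol-5-yl on the sulfonyl sulfur gives a 1800-fold lower number from compound 1 to compound 4 (3.26 log units; beyond the scatter), so the group on this sulfur can govern the activity of the series to a degree the earlier compounds did not reveal. Going by these compounds alone, the only earlier step in this part of the molecule, an at least 2.7-fold higher number from compound 1 to compound 2 (0.44 log units; beyond the scatter), showed only a loss, whereas the exchange of the whole aromatic group moves the number the other way and much further. Compound 4 also gives a clear number far from the end of the measurable range of this read-out, which matters for the series: the limit of > 5000 nM in this assay, at which 2 of the 4 values shown sit.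

From the compounds shown here alone, whether the gain comes from the carbon-only ring or from its two chlorine atoms stays open, and a plain phenyl group on the sulfonyl sulfur would begin to separate the two. The cause of the step is also unresolved, as is whether a pyridine ring or a methoxy-bearing phenyl group at this sulfur would keep the activity of compound 4.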